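The source may hold more compounds than are shown below. What is called first, only, known or untested is meant among the compounds shown, and "the series" means these compounds.

Three compounds have so far been measured in a functional assay on SK-BR-3 cells (Homo sapiens) for inhibition, read by CCK-8 assay, with a stated time of 72 h, tested at 20 uM; a higher number here means more inhibition of growth at the concentration tested, a lower number less inhibition of growth:

Compound 1 `CCOC(=O)/C=C1/C(=O)Nc2ccccc21`: 85.5%
Compound 2 `CC(C)(C)OC(=O)/C=C1/C(=O)Nc2ccccc21`: 87.3%
Compound 3 `Cc1ccc2c(c1)/C(=C\C(=O)OC(C)(C)C)C(=O)N2`: 88%

All three numbers are close to one another. Compound 2 sits among them with no separation that the measurement can resolve: the step from a number 1.8 percentage points higher from compound 1 to compound 2 (within the scatter) and the step from a number 0.7 percentage points higher from compound 2 to compound 3 (within the scatter) both lie within the usual scatter of repeated measurements. Nothing among these three compounds can therefore be called stronger or weaker than another.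

Compound 4 `COc1cccc2c1NC(=O)/C2=C/C(=O)OC(C)(C)C` is the next compound to be tested. It differs from compound 2 in one place: methoxy in place of hydrogen on an aromatic carbon. The change sits on an aromatic carbon of a six-membered aromatic ring of carbon only, part of a fused or bridged system of two rings, ortho to a fused ring.

Going by the values given here, the step that bears most directly on this is the one from compound 2 to compound 3, where a methyl entered on an aromatic carbon of the same ring and the number moved only within the scatter. On that basis no step beyond the scatter is expected in this assay, in either direction; the expected step from a number 1.3 percentage points lower from compound 2 to compound 4 (within the scatter) is small. Compound 4 is therefore estimated at 86%, with a range from 76% to 94%.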

Compound 4, percent growth inhibition at one concentration: 87.7%
Compound 4: middle estimate off by 1.7 percentage points, on the low side, and the stated range covers the measured number.
By their numbers in this assay, from the lowest: compounds 1, 2, 4 and 3 (each within the scatter of the next).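

In this assay the entry of methoxy, with 2 heavy atoms (1 carbon, 1 oxygen) and 1 hydrogen-bond acceptor, on an aromatic carbon ortho to a fused ring gives a number 0.4 percentage points higher from compound 2 to compound 4 (within the scatter) and so leaves no change that the measurement can resolve. Until now the only substituent tested on this ring was methyl, which gave a number 0.7 percentage points higher from compound 2 to compound 3 (within the scatter) and brought in no oxygen, so the new result extends what is seen on this ring from a plain carbon group to one joined through oxygen. Nothing measured here gives a reason for this result.

As far as these compounds go, whether the same holds for an amine, a carboxylic acid or a longer chain such as butoxy on this aromatic carbon remains open, since a small group that leaves the number in place says little about larger or charged ones. Also open, from the compounds shown here alone, is whether compound 2 and compound 4 would still match at lower concentrations, as a reading at a single concentration cannot show how much compound each needs to reach its effect.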